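This account rests on a few compounds, and the source may have more. Where it says the series, first, only, none or still open, it means among the compounds named here.

Compound 1 `Cc1ccc(-c2ccc(F)cc2)n1-c1ccc(-c2nc3ccc(F)cc3s2)cc1` and compound 2 `COc1ccc(-c2ccc(C)n2-c2ccc(-c3nc4ccc(F)cc4s3)cc2)cc1` share one core and differ in a single place. In a functional assay on MCF7 cells (Homo sapiens) for cytotoxicity, read by sulforhodamine B assay, with a stated time of 48 h (a lower number here means a stronger inhibitor of growth, a higher number a weaker inhibitor of growth), compound 1 gives 1790 nM, while compound 2 gives 2120 nM. The change between them is methoxy in place of fluoro on an aromatic carbon, and it produced a 1.2-fold higher number from compound 1 to compound 2 (0.07 log units; within the scatter).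

Compound 3 `COc1cc2nc(-c3ccc(-n4c(C)ccc4-c4ccc(F)cc4)cc3)sc2c(OC)c1OC` is built on a different core; the difference between the two cores is not broken down here. In this assay compound 3 gives 2670 nM, a number within the scatter of both compound 1 and compound 2. Compound 4 `COc1ccc(-c2ccc(C)n2-c2ccc(-c3nc4cc(OC)c(OC)c(OC)c4s3)cc2)cc1` has not yet been measured and stands to compound 3 exactly as compound 2 stands to compound 1: the change is methoxy in place of fluoro on an aromatic carbon, the same change at the same place, occurring twice among these four compounds.

Because a 1.2-fold higher number from compound 1 to compound 2 (0.07 log units; within the scatter) stayed within the scatter, the same change on compound 3 is expected to give a step of similar size, a 1.2-fold higher number from compound 3 to compound 4 (0.06 log units; within the scatter), which rests on that single earlier pair alone. Compound 4 is therefore estimated at 3100 nM in this assay, expected to fall between 1700 nM and 5600 nM.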

Compound 4, concentration for 50% growth inhibition: 1230 nM
For compound 4 the middle estimate is 2.5-fold (0.40 log units) above the measured one; the whole stated range lies above it.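

On the core of compound 3, the change from 4-fluorophenyl to 4-methoxyphenyl gave a 2.2-fold lower number from compound 3 to compound 4 (0.34 log units; beyond the scatter) in this assay, a modest step. Set beside the step on the core of compound 1, this one cannot be told apart from it, as the gap between them is no larger than two such steps can show by scatter alone: the same change on two cores in this assay, a 1.2-fold higher number (0.07 log units; within the scatter) from compound 1 to compound 2 and a 2.2-fold lower number (0.34 log units; beyond the scatter) from compound 3 to compound 4, 2.6-fold (0.41 log units) apart, within the scatter of two such steps. Among the compounds shown here, the two pairs therefore give no firm sign that the change behaves differently on the two cores, but they do not prove that it behaves alike, as they are only two pairs and just one of the steps lies beyond the scatter.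

The compounds shown leave open how other groups in the same place, such as an amine, a carboxylic acid or a longer alkoxy chain, would read in this assay. They also leave open whether the step from fluoro to methoxy would keep its size on any core other than these two.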